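The source may report more compounds than this note shows. Statements on the series, on what has been measured and on what is new or still open speak of the compounds shown alone.

Measured in an ADME assay on MDBK cells (Bos taurus) for cytotoxicity, read by MTT assay, with a stated time of 96 h; a higher number here means that more compound is tolerated, a lower number that less compound is tolerated:
- compound 1 `COc1ccc(-c2nc3cc(/C(C)=N/NC(N)=O)ccc3[nH]2)cc1`: 25000 nM
- compound 2 `COc1ccc(-c2nc3cc(/C(C)=N/NC(N)=S)ccc3[nH]2)cc1`: 13000 nM
- compound 3 `COc1ccc(-c2nc3cc(/C(C)=N/NC(N)=O)ccc3n2C2CCCCC2)cc1`: 54000 nM

On these three numbers, compound 1 at 25000 nM cannot be separated from compound 2, and only compound 3 stands clearly apart from it. The two measured steps are a 1.9-fold lower number from compound 1 to compound 2 (0.28 log units; within the scatter) and a 2.2-fold higher number from compound 1 to compound 3 (0.33 log units; beyond the scatter).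

The unmeasured compound 4 `C/C(=N\NC(N)=O)c1ccc2[nH]c(C3CCCCC3)nc2c1` differs from compound 1 in one place: cyclohexyl in place of 4-methoxyphenyl on an aromatic carbon. In words, this is cyclohexyl in place of 4-methoxyphenyl on an aromatic carbon.

Going by the values given here, no measured step changes that position, so the evidence is indirect. The step to compound 2 concerns a group on an amine nitrogen and says little here. The step to compound 3 is the nearer precedent, since cyclohexyl also enters there, but on an aromatic nitrogen, in place of hydrogen, and with 4-methoxyphenyl kept. That step, a 2.2-fold higher number from compound 1 to compound 3 (0.33 log units; beyond the scatter), is modest, and it points to a higher number.

In this assay, then, no change beyond the scatter is expected, with a slight lean upward. The estimated change is a 1.4-fold higher number from compound 1 to compound 4 (0.15 log units; within the scatter). For compound 4 the expected value is 35000 nM, with an estimated range from 12000 nM to 100000 nM.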

Compound 4, half-maximal cytotoxic concentration: > 100000 nM
Compound 4: no number, only a limit; the forecaster's own chance of this, stated with the estimate: 25%; at least 2.8-fold (0.45 log units) between middle value and limit.
By their numbers in this assay, from the lowest: compounds 2 and 1 (each within the scatter of the next); then compound 3. At a limit, above all of these: compound 4.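

In this assay, going by these compounds alone, the position on the aromatic carbon between two ring nitrogen atoms, which none of the earlier compounds varied, proves open to change: cyclohexyl in place of 4-methoxyphenyl gives an at least 4.0-fold higher number from compound 1 to compound 4 (0.60 log units; beyond the scatter), a step beyond the scatter. Compound 4 gives > 100000 nM, which is a limit and not a number, so this step has a lower bound but no upper one: the limit of > 100000 nM in this assay, at which 1 of the 4 values shown sits. Cyclohexyl on the aromatic nitrogen with 4-methoxyphenyl kept had given only a 2.2-fold higher number from compound 1 to compound 3 (0.33 log units; beyond the scatter), and compound 4, the only one of the four compounds without 4-methoxyphenyl, is also the only one that stands at a limit.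

The compounds shown do not separate the loss of the methoxy group from the loss of the aromatic ring, which a plain phenyl group at this position could do, and they do not show how a smaller group there, such as methyl or cyclopentyl, would read. On these data alone, it also remains open whether sulfur in place of oxygen on the side chain would keep compound 4 at the limit in this assay.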